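Swapping tert-butyl for trifluoromethyl on an aryl urea

The source may report more compounds than this note shows. Statements on the series, on what has been measured and on what is new or still open speak of the compounds shown alone.

Measured compounds:
compound 1, `Cc1ccccc1NC(=O)N[C@H](C)c1ccccc1`, 99%
compound 2, `CCc1ccccc1NC(=O)N[C@H](C)c1ccccc1`, 92%
compound 3, `C[C@@H](NC(=O)Nc1ccccc1C(C)(C)C)c1ccccc1`, 17%

These three share the same core and differ only in the group on the aromatic carbon of the aniline ring. In an ADME assay on the whole organism with Oryza sativa as the target, tested at 10 uM (a higher number here means a weaker effect of the compound at the concentration tested, a lower number a stronger effect), compound 3 stands lowest of the three: a number 75 percentage points lower from compound 2 to compound 3 (beyond the scatter) and a number 82 percentage points lower from compound 1 to compound 3 (beyond the scatter), both beyond the scatter, whereas a number 7 percentage points lower from compound 1 to compound 2 (within the scatter) stays within it.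

Compound 4, `C[C@@H](NC(=O)Nc1ccccc1C(F)(F)F)c1ccccc1`, is not yet measured. Relative to compound 3 the change is trifluoromethyl in place of tert-butyl on an aromatic carbon. The two steps that bear on it are those that brought tert-butyl onto this carbon: a number 82 percentage points lower from compound 1 to compound 3 (beyond the scatter) and a number 75 percentage points lower from compound 2 to compound 3 (beyond the scatter). Going by the values given here, both were large, so the number is sensitive to what sits on this aromatic carbon, yet none of the measured compounds carries trifluoromethyl, so the direction for compound 4 is uncertain. A rise back toward the values of compound 1 and compound 2 seems more likely than a further fall, but with a wide spread. Compound 4 is therefore expected at about 60% in this assay, between 20% and 95%, meaning an expected step of a number 43 percentage points higher from compound 3 to compound 4 (beyond the scatter).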

Compound 4, a percentage reported as activity, at one concentration (the size of the read-out at that concentration, not a potency): 54%
Compound 4: the middle estimate sits 6 percentage points above what was measured; low and high end bracket the measured number.
By their numbers in this assay, from the lowest: compound 3; then compound 4; then compounds 2 and 1 (each within the scatter of the next).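

In this assay, trifluoromethyl on this aromatic carbon gives a middle level, with a number 37 percentage points higher from compound 3 to compound 4 (beyond the scatter) and, on the other side, a number 38 percentage points lower from compound 2 to compound 4 (beyond the scatter) and a number 45 percentage points lower from compound 1 to compound 4 (beyond the scatter) in the same reading. The position therefore acts as more than a two-state switch, and tert-butyl and trifluoromethyl give clearly different numbers even though they carry the same count of heavy atoms. No measurement on hand explains that gap.

The compounds shown leave open whether an isopropyl group, a chlorine atom or a methoxy group on this carbon would also land at a middle level or would fall with one of the other compounds. They also cannot say whether trifluoromethyl on a different carbon of this ring would give a similar number.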